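A hydroxy added to the amide-linked compound 2

This account rests on a few compounds, and the source may have more. Where it says the series, first, only, none or still open, it means among the compounds named here.

Compound 2 `CN(C)C(=O)c1cc2cnc(Nc3ccc(C(=O)NCCCN=C=S)cc3)nc2n1C1CCCC1` gives 91.2% in a functional assay on NCI-H1299 cells (Homo sapiens) for inhibition, read by CCK-8 assay, with a stated time of 72 h, tested at 10 uM (a higher number here means a stronger effect of the compound at the concentration tested, a lower number a weaker effect), the highest of the three numbers measured. Compound 3 `CN(C)C(=O)c1cc2cnc(Nc3ccc(C(=O)NCCCCCCN=C=S)cc3)nc2n1C1CCCC1` gives 85%, and the step of a number 6.2 percentage points lower from compound 2 to compound 3 (within the scatter) lies within the scatter, so the two cannot be ranked. Compound 1 `CN(C)C(=O)c1cc2cnc(Nc3ccc(S(=O)(=O)NCCCN=C=S)cc3)nc2n1C1CCCC1` gives 72.8%; the step of a number 18.4 percentage points higher from compound 1 to compound 2 (beyond the scatter) lies beyond the scatter, as does a number 12.2 percentage points higher from compound 1 to compound 3 (beyond the scatter). Compound 4 `CN(C)C(=O)c1cc2cnc(Nc3ccc(C(=O)NCCCN=C=S)cc3O)nc2n1C1CCCC1` differs from compound 2 by hydroxy in place of hydrogen on an aromatic carbon. Among the measured compounds shown here, none of the measured steps concerns the aromatic ring; all three alter the chain or the group that carries it. The change in compound 4 thus lacks a precedent here, and the expected step of a number 5.2 percentage points lower from compound 2 to compound 4 (within the scatter) is small, probably within the scatter. Compound 4 is estimated at 86%, with a range from 68% to 96%.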

Compound 4, a percentage reported as inhibition, at one concentration (the size of the read-out at that concentration, not a potency): 24.2%
For compound 4 the middle estimate is 61.8 percentage points above the measured one, outside the stated range (below it).
By their numbers in this assay, from the lowest: compound 4; then compound 1; then compounds 3 and 2 (each within the scatter of the next).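

In this assay, among the compounds shown here, the step of a number 67 percentage points lower from compound 2 to compound 4 (beyond the scatter) comes from a single hydroxy on the aromatic carbon ortho to a large group, a part of the molecule that no earlier step touched. This position is therefore far from indifferent: one added heavy atom here moves the number more than any of the earlier changes to the chain or the group carrying it. Nothing available explains the drop.

Going by these compounds, whether the loss belongs to hydroxy itself or to any group at this place stays open. A methoxy or a fluorine on the same carbon would help separate the two.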